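The source may hold more compounds than are shown below. What is called first, only, known or untested is meant among the compounds shown, and "the series" means these compounds.

Measured in an ADME assay on Vero cells (Chlorocebus sabaeus) for cytotoxicity, read by CellTiter-Glo, with a stated time of 72 h; on this read-out lower numbers stand for higher toxicity in this test and higher numbers for lower toxicity in this test:
- compound 1 `[O-][n+]1nc(N[C@@H]2C[C@H]3CC[C@@H]2C3)[n+]([O-])c2ccccc21`: 3.4 ug/mL
- compound 2 `[O-][n+]1nc(NC2CC2)[n+]([O-])c2ccc(Cl)cc21`: 1.3 ug/mL
- compound 3 `[O-][n+]1nc(NC2CCC2)[n+]([O-])c2ccc(Cl)cc21`: 1.6 ug/mL

On these numbers, compound 3 sits level with compound 2 within the scatter, and both values lie under that of compound 1. The next compound to be tested is compound 4 `[O-][n+]1nc(N[C@@H]2C[C@H]3CC[C@@H]2C3)[n+]([O-])c2ccc(Cl)cc21`, which keeps the core of compound 3 and changes only the group on the nitrogen: a group of 7 heavy atoms (7 carbon; 2 five-membered non-aromatic rings of carbon only) in place of a group of 4 heavy atoms (4 carbon; one four-membered non-aromatic ring of carbon only), on a nitrogen on an aromatic ring.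

One measured step resembles this change, a swap of cyclopropyl for cyclobutyl on that nitrogen. It gave a 1.2-fold higher number from compound 2 to compound 3 (0.09 log units; within the scatter), so that smaller swap did little. Among the compounds with values here, compound 1 already carries the entering group on a different core and gives 3.4 ug/mL, which hints at a number that may be somewhat higher, although no measured pair isolates the effect of the core. A modest rise in this assay is therefore expected, and it may not clear the scatter. The expected step is a 1.3-fold higher number from compound 3 to compound 4 (0.10 log units; within the scatter). For compound 4 the estimated value is 2 ug/mL, with an expected range of 1 ug/mL to 3.8 ug/mL.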

Compound 4, half-maximal cytotoxic concentration: 1.1 ug/mL
Compound 4: middle estimate off by 1.8-fold (0.26 log units), on the high side; low and high end bracket the measured number.
By their numbers in this assay, from the lowest: compounds 4, 2 and 3 (each within the scatter of the next); then compound 1.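

In this assay, the group on the nitrogen can go from cyclobutyl or cyclopropyl to the much larger two-ring group without a change that clears the scatter: a 1.5-fold lower number from compound 3 to compound 4 (0.16 log units; within the scatter) and a 1.2-fold lower number from compound 2 to compound 4 (0.07 log units; within the scatter) are the steps. With that two-ring group held fixed, chloro in place of hydrogen on an aromatic carbon gives a 3.1-fold lower number from compound 1 to compound 4 (0.49 log units; beyond the scatter) and is the only step among these compounds beyond the scatter, so here the number moves with the chloro rather than with the size of the group on the nitrogen. Nothing measured alongside these compounds offers a reason for either observation. As far as these compounds go, whether an amine or a hydroxyl on the group at that nitrogen would move the number remains open. Also open, from the compounds shown here alone, is whether removing the chloro would have the same effect with cyclobutyl or cyclopropyl on the nitrogen.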